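Chloro on the ethoxy compound: a small step expected

The compounds below may be only part of what the source reports. "The series", "measured", "known", "first", "only" and "open" are said of these compounds alone.

Of the compounds shown here, three with a shared core have been measured in a functional assay on HeLa cells (Homo sapiens) for antiproliferative activity, read by CCK-8 assay, with a stated time of 72 h; on this read-out lower numbers stand for stronger inhibition and higher numbers for weaker inhibition. Compound 1 (`COc1ccc(-c2cncnc2-c2cc(OC)c(OC)c(OC)c2)cc1F`) gives 500 nM, compound 2 (`COc1ccc(-c2cncnc2-c2cc(OC)c(OC)c(OC)c2)cc1Cl`) gives 320 nM and compound 3 (`CCOc1ccc(-c2cncnc2-c2cc(OC)c(OC)c(OC)c2)cc1`) gives 250 nM. Compound 3 stands close to both others, with a 1.3-fold lower number from compound 2 to compound 3 (0.11 log units; within the scatter) and a 2.0-fold lower number from compound 1 to compound 3 (0.30 log units; within the scatter).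

Compound 4 (`CCOc1ccc(-c2cncnc2-c2cc(OC)c(OC)c(OC)c2)cc1Cl`) carries chloro in place of hydrogen on an aromatic carbon, ortho to an ethoxy group: chloro in place of hydrogen on an aromatic carbon. Going by the values given here, no measured pair shows this exact change. The closest evidence is a 1.6-fold lower number from compound 1 to compound 2 (0.19 log units; within the scatter), where chloro replaces fluoro, together with the step from compound 2 to compound 3 already given, where 4-ethoxyphenyl replaces 3-chloro-4-methoxyphenyl. Both steps stay within the scatter, so no step beyond the scatter is expected in this assay. The expected step is a 1.1-fold lower number from compound 3 to compound 4 (0.06 log units; within the scatter). The estimate for compound 4 is 220 nM, with an expected range from 90 nM to 520 nM.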

Compound 4, half-maximal inhibitory concentration: 90 nM
Compound 4: middle estimate off by 2.4-fold (0.39 log units), on the high side; measured number inside the range.
By their numbers in this assay, from the lowest: compound 4; then compounds 3, 2 and 1 (each within the scatter of the next).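

In this assay, going by these compounds alone, chloro in place of hydrogen on an aromatic carbon, ortho to an ethoxy group, gives a 2.8-fold lower number from compound 3 to compound 4 (0.44 log units; beyond the scatter) and so moves the number beyond the scatter, which no step among the first three compounds did. With chloro kept, methyl in place of hydrogen on the saturated chain carbon bound to the oxygen, which turns methoxy into ethoxy, gives a 3.6-fold lower number from compound 2 to compound 4 (0.55 log units; beyond the scatter) and also lies beyond the scatter, so in this small set both changes count when the other group is present. No measurement at hand explains either step.

Going by these compounds, whether bromo or trifluoromethyl at this same place would do as much as chloro remains open. So does whether a longer chain, such as propoxy, would lower the number further than ethoxy.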